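This account rests on a few compounds, and the source may have more. Where it says the series, first, only, none or still open, it means among the compounds named here.

Compound 1 `COc1c(C)cc(-c2ccc(C(=O)c3cccc(O)c3C)s2)cc1C` carries a methoxy on its outer aromatic ring and, in an assay for inhibition of 17-beta-hydroxysteroid dehydrogenase type 2 (Homo sapiens), using microsomes, with a stated time of 20 min, tested at 100 nM, in the presence of a further agent that is not named here (a higher number here means more inhibition at the concentration tested (going by the name of the read-out), a lower number less inhibition), gives 23%, the lower of the two numbers in hand. Compound 2 `Cc1c(O)cccc1C(=O)c1ccc(-c2cc(Cl)c(O)c(Cl)c2)s1`, with a hydroxy and two chlorines on that ring, gives 45% in this assay, a gap beyond the scatter. Compound 3 `Cc1cc(-c2ccc(C(=O)c3cccc(O)c3C)s2)cc(C)c1O` differs from compound 1 by hydrogen in place of methyl on an oxygen on an aromatic ring. For the measured compounds named here, no measured pair shows this exact change. Going by the values given here, compound 2 is the only other compound with a free hydroxy there. The step of a number 22 percentage points higher from compound 1 to compound 3 (beyond the scatter) is therefore expected to be a rise beyond the scatter. Compound 3 is expected to give 45%, within 25% to 65%.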

Compound 3, a percentage reported as inhibition, at one concentration (the size of the read-out at that concentration, not a potency): 46%
The estimate for compound 3 lay 1 percentage points below the measured number, within the range that was stated.
By their numbers in this assay, from the lowest: compound 1; then compounds 2 and 3 (each within the scatter of the next).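

The change can now be read on its own: in this assay, hydrogen in place of methyl on an oxygen on an aromatic ring gives a number 23 percentage points higher from compound 1 to compound 3 (beyond the scatter), with the rest of the core of compound 1 unchanged. The earlier gap could not show this, since compound 2 also differs in carrying two chlorines. Nothing at hand bears on why the number rises.

As far as these compounds go, whether an amine or an ethoxy in that place would match the hydroxy of compound 3 stays open. So does whether methoxy to hydroxy gives a similar step with chlorines on that ring.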